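A smaller chain end in place of a larger one

This account rests on a few compounds, and the source may have more. Where it says the series, first, only, none or still open, it means among the compounds named here.

Of the compounds shown here, two have been tested in a functional assay on the whole organism with Rattus norvegicus as the target, at a dose of 100 mg/kg; a lower number here means less inhibition, a higher number more inhibition at the dose given (going by the name of the read-out). Compound 1, `C/N=C(\S)NCCCCn1nc(C)ccc1=O`, gives 44.5% in this assay. Compound 2, `N#CNC(=N)NCCCCCCn1nc(-c2ccccc2)ccc1=O`, gives 20.5% in this assay, the lower of the two numbers, and the gap to compound 1 lies beyond the usual scatter of such measurements.

Compound 3, `C/N=C(\S)NCCCCn1nc(-c2ccccc2)ccc1=O`, has not yet been measured. It is drawn from compound 2 by a single change: a group of 5 heavy atoms (2 carbon, 2 nitrogen, 1 sulfur; no ring) in place of a group of 8 heavy atoms (4 carbon, 4 nitrogen; no ring), on a saturated chain carbon, four bonds along the chain from an aromatic nitrogen. For the measured compounds named here, compound 1 carries the same chain end that enters in compound 3, but differs from compound 3 in other places, so no step between measured compounds isolates this change.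

Going by the values given here, with only two measured points and no shared step, the account expects a modest rise in this assay from compound 2 to compound 3, of a size that may not clear the scatter, the expected step being a number 10.5 percentage points higher from compound 2 to compound 3 (beyond the scatter). Compound 3 is therefore estimated to give 31% in this assay, within a range from 12% to 52%.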

Compound 3, a percentage reported as inhibition, in the whole organism at one dose (the size of the read-out at that dose, not a potency): 87.1%
Compound 3: middle estimate off by 56.1 percentage points, on the low side; measured number outside the range, above it.
By their numbers in this assay, from the lowest: compound 2; then compound 1; then compound 3.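

In this assay, the position on a saturated chain carbon, four bonds along the chain from an aromatic nitrogen, proves highly sensitive to what it carries: the group of 5 heavy atoms (2 carbon, 2 nitrogen, 1 sulfur; no ring) in place of the group of 8 heavy atoms (4 carbon, 4 nitrogen; no ring) gives a number 66.6 percentage points higher from compound 2 to compound 3 (beyond the scatter). With that chain end held constant, phenyl in place of methyl on an aromatic carbon also has a large effect, giving a number 42.6 percentage points higher from compound 1 to compound 3 (beyond the scatter), so the part played by the aromatic carbon's substituent can now be read separately, which the two earlier compounds, differing in more than one place, did not allow. Nothing measured here accounts for either step.

For the compounds shown here, the phenyl step is seen only with the sulfur-bearing chain end, and the chain-end step only with phenyl, so it remains open whether each would keep its size with the other group changed. From the compounds shown here alone, it is also open how this position would respond to a urea or a primary amine as the chain end, or how the aromatic carbon would respond to a benzyl group.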